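Cytotoxicity notes on a thioether series, compound 3 to 4

The source may report more compounds than this note shows. Statements on the series, on what has been measured and on what is new or still open speak of the compounds shown alone.

Measured in an ADME assay on HEL cells (Homo sapiens) for cytotoxicity, with a stated time of 3 days (a lower number here means that less compound is tolerated, a higher number that more compound is tolerated), so far:
- compound 1 `C=Cc1ccc(-c2cc(C)c3ncc(CSCc4ccccc4)n3c2)cc1` gives >= 100 ug/mL, a limit of the assay.
- compound 2 `Cc1cc(-c2ccsc2)cn2c(CSCc3ccccc3)cnc12` gives 4 ug/mL.
- compound 3 `Cc1cc(-n2cccc2)cn2c(CSCCc3ccccc3)cnc12` gives >= 4 ug/mL, again a limit of the assay.

Compound 3 therefore stands only at a limit in this assay, with no exact number; its value sits at the limit of >= 4 ug/mL in this assay, at which 1 of the 3 values shown sits, while compound 1 sits at the limit of >= 100 ug/mL in this assay, at which 1 of the 3 values shown sits. For the measured compounds named here, the one measured step, an at least 25-fold lower number from compound 1 to compound 2 (1.39 log units; beyond the scatter), concerns the aromatic group on the core and not the thioether chain.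

Compound 4 `Cc1cc(-n2cccc2)cn2c(CSCc3ccccc3)cnc12` differs from compound 3 by phenyl in place of benzyl on a saturated chain carbon bound to a sulfur. Going by the values given here, no measured step in this assay touches this part of the molecule, so nothing among the measured compounds speaks for a change beyond the scatter in either direction. The expected step is therefore a step that the limit leaves unreadable from compound 3 to compound 4, the value of compound 3 being only a limit in this assay.

For compound 4 the estimated value in this assay is 6 ug/mL, with a range from 2 ug/mL to 40 ug/mL.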

Compound 4, minimum cytotoxic concentration: 20 ug/mL
For compound 4 the middle estimate is 3.3-fold (0.52 log units) below the measured one; measured number inside the range.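

In this assay, for the compounds shown here, compound 4 gives 20 ug/mL, which is the first exact number for the 1H-pyrrol-1-yl group on the aromatic carbon of the shared core. The change from phenethyl to benzyl on the sulfur still cannot be read from compound 3 to compound 4, because compound 3 stands only at a limit: the limit of >= 4 ug/mL in this assay, at which 1 of the 4 values shown sits. With benzyl on the sulfur held constant, the group on the aromatic carbon shifts the number in both directions, with a 5.0-fold higher number from compound 2 to compound 4 (0.70 log units; beyond the scatter) and an at least 5.0-fold lower number from compound 1 to compound 4 (0.69 log units; beyond the scatter), so the 1H-pyrrol-1-yl group gives a number on the tolerated side of the thiophen-3-yl group and on the less tolerated side of the 4-vinylphenyl group.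

Going by these compounds alone, how much the thioether chain itself contributes remains open, since the only pair that differs there has no exact number on the phenethyl side. Also open, as far as these compounds go, is whether a longer chain on the sulfur, or an amine in place of the 1H-pyrrol-1-yl group on the aromatic carbon, would fit the steps seen so far in this assay.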